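A few compounds are considered here, and "the series" means these few. Any claim that something is new, unique, unknown or untested is made for them only; others in the source may bear on it.

Compound 1 `COc1cc(C(=O)N(C)C)nn1-c1ccccc1` — 47.5%
Compound 2 `COc1cc(C(=O)NC(C)C)nn1-c1ccccc1` — 24.8%
Compound 3 `COc1cc(C(=O)N(C)c2ccc(C)cc2)nn1-c1ccccc1` — 22.3%

In a functional assay on the whole organism (strain Wistar) for inhibition, with Rattus norvegicus as the target, read by paw edema, with stated times of 30 min and 3 h, at a dose of 100 mg/kg by the oral route (a lower number here means less inhibition, a higher number more inhibition at the dose given (going by the name of the read-out)), compound 1 stands highest of the three measured compounds. Both measured steps leave from it and both fall on the amide side of the shared core: the step of a number 22.7 percentage points lower from compound 1 to compound 2 (beyond the scatter) follows isopropylamino in place of dimethylamino on a carbonyl carbon, and the step of a number 25.2 percentage points lower from compound 1 to compound 3 (beyond the scatter) follows 4-methylphenyl in place of methyl on an amide-type nitrogen. Each of these is a modest drop that lies beyond the scatter.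

Compound 4 `CCCCCOc1cc(C(=O)N(C)C)nn1-c1ccccc1` is not yet measured. It differs from compound 1 by butyl in place of hydrogen on a saturated chain carbon bound to an oxygen on an aromatic ring, that is, methoxy to pentyloxy, while the dimethylamino on the carbonyl carbon is kept. Within the data shown here, neither measured step touches this part of the molecule, so no measured step bears on the change, and the data give no direction for it. The step of a number 5.5 percentage points lower from compound 1 to compound 4 (within the scatter) is therefore expected to stay within the scatter, with a wide range around that expectation. For compound 4 in this assay the estimate is 42%, between 20% and 62%.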

Compound 4, a percentage reported as inhibition, in the whole organism at one dose (the size of the read-out at that dose, not a potency): 20%
For compound 4 the middle estimate is 22 percentage points above the measured one; the measured number falls inside the stated range.
By their numbers in this assay, from the lowest: compounds 4, 3 and 2 (each within the scatter of the next); then compound 1.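

In this assay, the change from methoxy to pentyloxy, with the dimethylamino on the carbonyl carbon kept, gives a number 27.5 percentage points lower from compound 1 to compound 4 (beyond the scatter). This shows that the group on the oxygen also matters, whereas the earlier steps had shown a loss only on the amide side of the shared core. Compound 1 now stands above its single-change neighbours at both places, although no available evidence accounts for the drop at this position.

With only methoxy and pentyloxy at this position, the compounds shown leave open how the number changes through ethoxy, propyloxy or butyloxy, and whether a branched isopropoxy or a chain ending in a hydroxyl would behave like the pentyl chain. They also leave open how pentyloxy would read with isopropylamino in place of dimethylamino on the carbonyl carbon.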